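A few compounds are considered here, and "the series" means these few. Any claim that something is new, unique, unknown or untested is made for them only; others in the source may bear on it.

Compound 3 `Cn1c(CN2CCN(c3ccccc3C(F)(F)F)CC2)nc2ccccc21` and compound 1 `Cn1c(CN2CCC(c3ccccc3C(F)(F)F)CC2)nc2ccccc21` carry the same trifluoromethyl-bearing aromatic ring on different cores. In an assay on CHO cells with metabotropic glutamate receptor 2 (Homo sapiens) as the target, read by FLIPR (a higher number here means that more compound is needed for the effect, a lower number that less compound is needed), compound 3 gives 316 nM, and compound 1 gives 316 nM, level at the digits seen. The difference between the two cores is not broken down here. Compound 2 `Cn1c(CN2CCN(c3ccccc3F)CC2)nc2ccccc21` differs from compound 3 by fluoro in place of trifluoromethyl on an aromatic carbon, and the step of a 2.5-fold higher number from compound 3 to compound 2 (0.40 log units; beyond the scatter) in this assay is modest but beyond the scatter, with compound 2 giving 794 nM. Compound 4 `Cn1c(CN2CCC(c3ccccc3F)CC2)nc2ccccc21` is not yet measured in this assay. Against compound 1 it carries the same change, (fluoro in place of trifluoromethyl on an aromatic carbon). Because the step of a 2.5-fold higher number from compound 3 to compound 2 (0.40 log units; beyond the scatter) is modest but beyond the scatter, and because compound 1 gives 316 nM level with compound 3, compound 4 is expected to show the same step as a 2.5-fold higher number from compound 1 to compound 4 (0.40 log units; beyond the scatter). For compound 4 the estimate in this assay is 794 nM, with a range from 400 nM to 1600 nM.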

Compound 4, half-maximal effective concentration: 126 nM
The estimate for compound 4 lay 6.3-fold (0.80 log units) above the measured number, and the stated range ends above it.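

In this assay, fluoro in place of trifluoromethyl on an aromatic carbon gives on the core of compound 1 a 2.5-fold lower number from compound 1 to compound 4 (0.40 log units; beyond the scatter). The change therefore does not carry from one core to the other in this series, neither in size nor in direction: the same change on two cores in this assay, a 2.5-fold higher number (0.40 log units; beyond the scatter) from compound 3 to compound 2 and a 2.5-fold lower number (0.40 log units; beyond the scatter) from compound 1 to compound 4, 6.3-fold (0.80 log units) apart, beyond the scatter of two such steps.
With one pair on each core, this shows that the result of the change depends on the core, but it does not show which feature of the cores is responsible, or whether other changes would fail to carry as well.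

Still open, on these data alone, is whether a chloro, a methoxy or a nitrile in the same place would rank the same way on both cores. Also open, as far as these compounds go, is whether a plain hydrogen there would fall in line with fluoro or with trifluoromethyl on either core.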